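Aminomethyl for hydroxymethyl on the chloropyridinyl sulfonamide

The source may hold more compounds than are shown below. What is called first, only, known or untested is meant among the compounds shown, and "the series" means these compounds.

Compound 3 `N#Cc1ccc(O[C@H]2CN(S(=O)(=O)c3ccc(Cl)cn3)C[C@@]2(O)CO)cc1F` gives 170 mL/min/kg in an ADME assay on the whole organism (Rattus norvegicus, strain Sprague-Dawley) for pharmacokinetics, read by LC-MS, with a stated time of 30 min, at a dose of 1 mg/kg by the intravenous route (a higher number here means faster removal of the compound, a lower number slower removal), the lowest of the three numbers in hand. Compound 2 `N#Cc1ccc(O[C@H]2CN(S(=O)(=O)c3ccccc3C#N)C[C@@]2(O)CO)cc1F` gives 200 mL/min/kg, and the step of a 1.2-fold lower number from compound 2 to compound 3 (0.07 log units; within the scatter) is a change of the aryl on the sulfonyl sulfur and is within the scatter. Compound 1 `N#Cc1ccc(O[C@H]2CN(S(=O)(=O)c3ccc(Cl)cc3Cl)C[C@@]2(O)CN)cc1F` gives 1100 mL/min/kg; it differs from compound 3 in two places at once, so only the two values themselves can be compared, and they lie far apart.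

Compound 4 `N#Cc1ccc(O[C@H]2CN(S(=O)(=O)c3ccc(Cl)cn3)C[C@@]2(O)CN)cc1F` takes the step (amino in place of hydroxy on a saturated chain carbon bound to a saturated ring carbon). For the measured compounds named here, no measured step bears directly on this change; the only single-point step in hand, that from compound 2 to compound 3, concerns the sulfonyl aryl and not the chain carbon. Going by the values given here, the one compound carrying the aminomethyl, compound 1, shows the highest number. Its aryl also differs from that of compound 3, so the two changes cannot be told apart in that comparison.

The expectation for compound 4 is therefore a number somewhat higher than that of compound 3, with a wide range, expressed as the step of a 2.4-fold higher number from compound 3 to compound 4 (0.37 log units; beyond the scatter). Compound 4 is estimated at 400 mL/min/kg, within 170 mL/min/kg to 1100 mL/min/kg.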

Compound 4, clearance: 320 mL/min/kg
Beside the measured number, compound 4's estimate is 1.3-fold (0.10 log units) above it, within the range that was stated.
By their numbers in this assay, from the lowest: compounds 3, 2 and 4 (each within the scatter of the next); then compound 1.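

On the 5-chloropyridin-2-yl sulfonamide, hydroxymethyl to aminomethyl can now be read as a single change at this position: this assay gives a 1.9-fold higher number from compound 3 to compound 4 (0.27 log units; within the scatter) and so does not separate the two groups on this aryl. With the aminomethyl held constant, the change of 2,4-dichlorophenyl to 5-chloropyridin-2-yl on the sulfonyl sulfur gives a 3.4-fold lower number from compound 1 to compound 4 (0.54 log units; beyond the scatter) and lies beyond the scatter, so the aminomethyl alone does not carry the high number of compound 1 and the sulfonyl aryl accounts for a measurable part of the gap in this one pair. The data in hand offer no explanation for either step.

As far as these compounds go, each reading rests on a single pair, so it remains open whether hydroxymethyl and aminomethyl also stay within the scatter of each other with 2,4-dichlorophenyl or 2-cyanophenyl on the sulfonyl sulfur. Also open, from the compounds shown here alone, is how far this position tolerates other groups in this assay, such as a dimethylaminomethyl, a carboxylic acid or a longer chain like 2-aminoethyl on the same saturated ring carbon.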